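The source may hold more compounds than are shown below. What is called first, only, known or untested is meant among the compounds shown, and "the series" means these compounds.

In an ADME assay on Huh7.5.1 cells (Homo sapiens) for cytotoxicity, read by ATP content, with a stated time of 48 h (on this read-out lower numbers stand for higher toxicity in this test and higher numbers for lower toxicity in this test), compound 3 `Cc1oc(-c2c(F)cccc2F)nc1CN1CCC(C(=O)NCCCN2C[C@H](C)C[C@H](C)C2)CC1` gives 32700 nM, the highest of the three numbers recorded. Compound 2 `Cc1ccccc1-c1nc(CN2CCC(C(=O)NCCCN3[C@H](C)CCC[C@@H]3C)CC2)c(C)o1` gives 21300 nM, which lies within the scatter of compound 3, while compound 1 `CC[C@@H]1C[C@H](CC)CN(CCCNC(=O)C2CCN(Cc3nc(-c4ccccc4C)oc3C)CC2)C1` gives 3470 nM, a gap beyond the scatter. Compound 4 `COc1cccc(OC)c1-c1nc(CN2CCC(C(=O)NCCCN3C[C@H](C)C[C@H](C)C3)CC2)c(C)o1` differs from compound 3 at a single place: 2,6-dimethoxyphenyl in place of 2,6-difluorophenyl on an aromatic carbon. Within the data shown here, the one step measured so far, a 6.1-fold higher number from compound 1 to compound 2 (0.79 log units; beyond the scatter), swapped the dimethylpiperidin-1-yl and diethylpiperidin-1-yl groups at the other end of the molecule, not the aromatic group altered here, so it does not bear directly on this change, and no measured pair varies the aromatic group alone. With nothing to anchor a direction, the expected step is a 1.1-fold lower number from compound 3 to compound 4 (0.04 log units; within the scatter), within the scatter. Compound 4 is therefore estimated at 30000 nM, with a range from 12000 nM to 80000 nM.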

Compound 4, half-maximal cytotoxic concentration: 77100 nM
Beside the measured number, compound 4's estimate is 2.6-fold (0.41 log units) below it; the measured number falls inside the stated range.
By their numbers in this assay, from the lowest: compound 1; then compounds 2 and 3 (each within the scatter of the next); then compound 4.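

In this assay the aromatic group on this carbon of the five-membered ring does shift the number: 2,6-dimethoxyphenyl in place of 2,6-difluorophenyl gives a 2.4-fold higher number from compound 3 to compound 4 (0.37 log units; beyond the scatter) and so a modest step toward lower toxicity in this test. Among these compounds, the one earlier step changed the other end of the molecule, so this is the first sign that this position matters too. Nothing measured here gives a reason for this step. Still open, going by these compounds, is how plain phenyl or 2,6-dichlorophenyl would compare at this position. On these data alone, whether the same swap gives a similar step with a different amine at the other end also remains open.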